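The compounds below may be only part of what the source reports. "The series", "measured", "known", "first", "only" and "open" are said of these compounds alone.

Compound 1 `COc1cc2c(Oc3ccc(NC(=O)c4nnn(-c5ccccc5C(F)(F)F)c4C(F)(F)F)cc3F)ccnc2cc1OCCCN1CCCC1`: 210 nM
Compound 2 `COc1cc2c(Oc3ccc(NC(=O)c4nnn(-c5ccc(C)cc5)c4C(F)(F)F)cc3F)ccnc2cc1OCCCN1CCC(C)CC1`: 1200 nM

In a functional assay on HT-29 cells (Homo sapiens) for cytotoxicity, read by MTT assay, with a stated time of 72 h (on this read-out lower numbers stand for stronger inhibition and higher numbers for weaker inhibition), compound 2 gives the higher of the two numbers; compound 1 gives a number that is lower by more than the usual scatter. Compound 3 `COc1cc2c(Oc3ccc(NC(=O)c4nnn(-c5ccccc5C(F)(F)F)c4C(F)(F)F)cc3F)ccnc2cc1OCCCN1CCC(C)CC1` has not yet been measured. It differs from compound 2 by 2-(trifluoromethyl)phenyl in place of 4-methylphenyl on an aromatic nitrogen, so that compound 3 carries the same 2-(trifluoromethyl)phenyl group as compound 1 while keeping the remainder of compound 2. The expected step of a 3.0-fold lower number from compound 2 to compound 3 (0.48 log units; beyond the scatter) in this assay runs downward, toward stronger inhibition, beyond the scatter. For compound 3 the estimate is 400 nM, with a range from 150 nM to 1200 nM.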

Compound 3, half-maximal inhibitory concentration: 200 nM
Beside the measured number, compound 3's estimate is 2.0-fold (0.30 log units) above it; the range from low to high includes it.
By their numbers in this assay, from the lowest: compounds 3 and 1 (each within the scatter of the next); then compound 2.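

In this assay, 2-(trifluoromethyl)phenyl in place of 4-methylphenyl on the aromatic nitrogen gives a 6.0-fold lower number from compound 2 to compound 3 (0.78 log units; beyond the scatter), so the group at this position matters while 4-methylpiperidin-1-yl stays fixed. With 2-(trifluoromethyl)phenyl held constant, 4-methylpiperidin-1-yl in place of pyrrolidin-1-yl gives a 1.1-fold lower number from compound 1 to compound 3 (0.02 log units; within the scatter), which leaves those two amines indistinguishable here. Nothing measured on these compounds accounts for the step at the aromatic nitrogen.

From the compounds shown here alone, it remains open whether 2-methylphenyl, 2-chlorophenyl or 4-(trifluoromethyl)phenyl would match 2-(trifluoromethyl)phenyl. Going by these compounds, it is also open whether the step from 4-methylphenyl would be the same with pyrrolidin-1-yl on the chain.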